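Nitro in place of chloro on two cores

The compounds below may be only part of what the source reports. "The series", "measured", "known", "first", "only" and "open" are said of these compounds alone.

Measured so far in this series:
compound 1 `COC(=O)C1(c2ccc([N+](=O)[O-])cc2)CC1CN1CCC(Cc2ccccc2)CC1` — 0.68 nM
compound 3 `COC(=O)C1(c2ccc(Cl)cc2)CC1CN1CCC(Cc2ccccc2)CC1` — 0.82 nM
compound 2 `COC(=O)C1(c2ccc(Cl)cc2)CC1CN1CCN(c2ncccn2)CC1` — 350 nM

In an assay for displacement of a labelled ligand from Sigma non-opioid intracellular receptor 1 (Cavia porcellus) (on this read-out higher numbers stand for weaker inhibition and lower numbers for stronger inhibition), compound 3 gives 0.82 nM and compound 1 gives 0.68 nM. The two share one core and differ only in nitro in place of chloro on an aromatic carbon, which gives the step of a 1.2-fold lower number from compound 3 to compound 1 (0.08 log units; within the scatter). Compound 2 stands on another core; in this assay compound 2 gives 350 nM, the highest number of the three, and its gap to compound 3 and to compound 1 lies beyond the scatter. How the two cores differ is not broken down here.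

Compound 4 `COC(=O)C1(c2ccc([N+](=O)[O-])cc2)CC1CN1CCN(c2ncccn2)CC1` is not yet measured. It stands to compound 2 as compound 1 stands to compound 3: the change is nitro in place of chloro on an aromatic carbon, the same change as the one already measured. Since the measured step of a 1.2-fold lower number from compound 3 to compound 1 (0.08 log units; within the scatter) stayed within the scatter, the step from compound 2 to compound 4 is expected to be small as well, about a 1.2-fold lower number from compound 2 to compound 4 (0.07 log units; within the scatter). For compound 4 in this assay the estimate is 300 nM, expected to fall between 120 nM and 750 nM.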

Compound 4, inhibition constant: 619 nM
Compound 4: middle estimate off by 2.1-fold (0.31 log units), on the low side; the range from low to high includes it.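

In this assay, nitro in place of chloro on the core of compound 2 gives a 1.8-fold higher number from compound 2 to compound 4 (0.25 log units; within the scatter). Set beside the earlier step, the two cores show no difference that can be told apart from the scatter: the same change on two cores in this assay, a 1.2-fold lower number (0.08 log units; within the scatter) from compound 3 to compound 1 and a 1.8-fold higher number (0.25 log units; within the scatter) from compound 2 to compound 4, 2.1-fold (0.33 log units) apart, within the scatter of two such steps. The change therefore carries across these two cores without a step beyond the scatter, but this does not show that it would do so on a third core, and with one pair per core the opposite directions of the two steps cannot be read as real.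

The compounds shown leave open whether a different group on the same aromatic carbon, such as an amine, a carboxylic acid or a methoxy group, would stay as close to chloro and nitro on either core. Also open, as far as these compounds go, is whether the same holds once the methyl ester shared by all these compounds gives way to a carboxylic acid or an amide.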